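Replacing carboxy with fluoro in compound 2

The source may hold more compounds than are shown below. What is called first, only, known or untested is meant among the compounds shown, and "the series" means these compounds.

Compound 2 `O=C(O)c1ccc(C(=O)/C(=C\c2ccc(F)c([N+](=O)[O-])c2)SCc2ccc(F)cc2)cc1` stands only at a limit in a physicochemical assay for solubility; on this read-out lower numbers stand for lower solubility and higher numbers for higher solubility. There, compound 2 gives < 1000 ug/mL, a limit and not a number. Compound 1 `O=C(O)c1ccc(C(=O)/C(=C\c2ccc(F)c([N+](=O)[O-])c2)Sc2ccc(Br)cc2)cc1` gives < 1000 ug/mL, also a limit. Compound 3 `O=C(O)c1ccc(C(=O)/C(=C\c2ccc(F)c([N+](=O)[O-])c2)SCc2ccccc2Cl)cc1` gives < 1000 ug/mL, again a limit. The whole set therefore reads as the limit of < 1000 ug/mL in this assay, at which 3 of the 3 values shown sit.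

Three measured steps are available: a step that the two limits leave unreadable from compound 1 to compound 2, a step that the two limits leave unreadable from compound 1 to compound 3 and a step that the two limits leave unreadable from compound 2 to compound 3. All three change the group on sulfur and keep the carboxy, and none has a readable size.

Compound 4 `O=C(/C(=C\c1ccc(F)c([N+](=O)[O-])c1)SCc1ccc(F)cc1)c1ccc(F)cc1` differs from compound 2 by fluoro in place of carboxy on an aromatic carbon, or 4-carboxyphenyl to 4-fluorophenyl. Among the measured compounds shown here, no measured step touches the carboxy, so the data give no measured size for this change.

The expected step is a step that the limit leaves unreadable from compound 2 to compound 4, tentatively taken as downward in this assay. Compound 4 is estimated at 100 ug/mL, with an expected range of 5 ug/mL to 900 ug/mL, and a further limit is the likeliest report.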

Compound 4, solubility: < 1000 ug/mL
Compound 4: no number, only a limit (the forecaster's own chance of this, stated with the estimate: 85%); the middle value lies beyond the limit too.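

In this assay compound 4 gives < 1000 ug/mL, a limit and not a number. Compound 2 also stands at a limit, and no new step can be read between compound 2 and compound 4. The compounds shown leave open the direction and size of the change from carboxy to fluoro.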